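Swapping an Aminophenyl for a Methylphenyl in a Cytotoxicity Series

This account rests on a few compounds, and the source may have more. Where it says the series, first, only, none or still open, it means among the compounds named here.

Compound 1 `COC(=O)c1ccc(NCc2cncn2Cc2ccccc2N)cc1-c1ccccc1` is the reference here. Within the data shown here, in a toxicity assay on NIH3T3 cells (Mus musculus) for cytotoxicity, read by resazurin assay (on this read-out higher numbers stand for an effect only at larger amounts of compound and lower numbers for an effect already at smaller amounts), compound 1 gives 25000 nM, the only plain number in this set, standing apart from the limit of > 10000 nM in this assay, at which 1 of the 2 values shown sits. Compound 2 `c1ccc(-c2ccc(Cn3cncc3CNc3ccc(-c4onc5ccccc45)c(-c4ccccc4)c3)cc2)cc1` is known in this assay only as a limit, > 10000 nM. Compound 3 `COC(=O)c1ccc(NCc2cncn2Cc2ccc(C)cc2)cc1-c1ccccc1` has not yet been measured; it differs from compound 1 by one change (4-methylphenyl in place of 2-aminophenyl on a saturated chain carbon bound to an aromatic nitrogen). Among the measured compounds shown here, no measured pair shows such a change, so the step from compound 1 to compound 3 is expected to stay within the usual scatter, without a clear direction. Compound 3 is expected to give about 22000 nM in this assay, with a range from 8000 nM to 60000 nM. The expected step is a 1.1-fold lower number from compound 1 to compound 3 (0.06 log units; within the scatter).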

Compound 3, half-maximal effective concentration: 50000 nM
The estimate for compound 3 lay 2.3-fold (0.36 log units) below the measured number; measured number inside the range.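

In this assay, among these compounds, the first measured step at this place is a 2.0-fold higher number from compound 1 to compound 3 (0.30 log units; within the scatter). This change takes away the hydrogen-bond donor and acceptor counted on 2-aminophenyl and brings in none, yet the values of the two compounds stay within the usual scatter of each other. So, for this one pair, the amino group is not shown to matter for this read-out.

From the compounds shown here alone, compound 2 differs in more than one place and is known only as a limit, so it offers no comparison: the limit of > 10000 nM in this assay, at which 1 of the 3 values shown sits. Whether a carboxylic acid or a longer chain at this place would shift the number beyond the scatter remains open.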